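Swapping the benzyl ring substituent on compound 2

The source may report more compounds than this note shows. Statements on the series, on what has been measured and on what is new or still open speak of the compounds shown alone.

Measured compounds:
compound 1 `Cc1cc(-c2ccccc2)n(/C(N)=N/S(=O)(=O)c2cc(C)c(Cl)cc2SCc2cccc3ccccc23)n1`, 7000 nM
compound 2 `Cc1ccc(CSc2cc(Cl)c(C)cc2S(=O)(=O)/N=C(\N)n2nc(C)cc2-c2ccccc2)cc1`, 28000 nM
compound 3 `Cc1cc(S(=O)(=O)/N=C(\N)n2nccc2-c2ccccc2)c(SCc2cccc(Cl)c2)cc1Cl`, 7000 nM

In a functional assay on HCT-116 cells (Homo sapiens) for cytotoxicity, read by MTT assay, with a stated time of 72 h (a higher number here means a weaker inhibitor, a lower number a stronger inhibitor), compound 2 gives the highest of the three numbers, so it is the weakest inhibitor here. The new compound 4 `Cc1cc(-c2ccccc2)n(/C(N)=N/S(=O)(=O)c2cc(C)c(Cl)cc2SCc2cccc(C(F)(F)F)c2)n1` differs from compound 2 in one place: 3-(trifluoromethyl)phenyl in place of 4-methylphenyl on a saturated chain carbon bound to a sulfur. Going by the values given here, the only single-change step bearing on this position is a 4.0-fold higher number from compound 1 to compound 2 (0.60 log units; beyond the scatter), which shows the group on the sulfur-bound chain carbon matters. Among the compounds with values here, compound 3, built on a different core, carries a chlorophenyl there and gives 7000 nM, though no single step links it to compound 2. A moderate move back toward lower numbers is expected, a 2.8-fold lower number from compound 2 to compound 4 (0.45 log units; beyond the scatter), giving an estimated 10000 nM for compound 4, in the range 4000 nM to 25000 nM.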

Compound 4, half-maximal inhibitory concentration: 19000 nM
The estimate for compound 4 lay 1.9-fold (0.28 log units) below the measured number, and the stated range covers the measured number.
By their numbers in this assay, from the lowest: compounds 1 and 3 (each within the scatter of the next); then compounds 4 and 2 (each within the scatter of the next).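

In this assay, this swap gives a 1.5-fold lower number from compound 2 to compound 4 (0.17 log units; within the scatter), so 3-(trifluoromethyl)phenyl and 4-methylphenyl on this chain carbon cannot be told apart. On the shared core, naphthalen-1-yl now stands apart from both groups: replacing it gives a 2.7-fold higher number from compound 1 to compound 4 (0.43 log units; beyond the scatter), alongside a 4.0-fold higher number from compound 1 to compound 2 (0.60 log units; beyond the scatter), in this assay. No measurement here explains this difference. The swap changes both the substituent and its ring position, so those two changes cannot be separated. On these data alone, whether an amine or a carboxylic acid on this ring would match naphthalen-1-yl remains open.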